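A few compounds are considered here, and "the series" means these few. Any claim that something is new, unique, unknown or untested is made for them only; others in the source may bear on it.

Measured so far:
compound 1, `O=C(Nc1cccc(CNc2nccnc2Cl)c1)Nc1ccc(F)c(Cl)c1`, gives 6750 nM in a functional assay on HepG2 cells (Homo sapiens) for antiproliferative activity, read by MTT assay, with a stated time of 48 h; a higher number here means a weaker inhibitor, a lower number a stronger inhibitor
compound 2, `O=C(Nc1cccc(CNc2nccnc2Cl)c1)Nc1cccc(C(F)(F)F)c1`, gives 6210 nM in this assay
compound 3, `CC(C)(C)c1ccc(NC(=O)Nc2cccc(CNc3nccnc3Cl)c2)cc1`, gives 7550 nM in this assay

The three share one core and differ only in the aryl group on the far side of the urea. Compound 1 sits among them with its number between those of compound 2 and compound 3, and both gaps lie within the usual scatter, so nothing separates the three. Compound 4, `Cc1ccc(NC(=O)Nc2cccc(CNc3nccnc3Cl)c2)cc1Cl`, is not yet measured. It differs from compound 1 in one place: methyl in place of fluoro on an aromatic carbon. Among the measured compounds shown here, with no measured pair showing what this change does, and the three known values all close together, the step from compound 1 to compound 4 is expected to be small, a 1.0-fold higher number from compound 1 to compound 4 (0.00 log units; within the scatter), in no settled direction. Compound 4 is therefore estimated at 6800 nM, within 3400 nM to 13600 nM.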

Compound 4, half-maximal inhibitory concentration: 11300 nM
Beside the measured number, compound 4's estimate is 1.7-fold (0.22 log units) below it; the range from low to high includes it.
By their numbers in this assay, from the lowest: compounds 2, 1, 3 and 4 (each within the scatter of the next).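

In this assay, among the compounds shown here, methyl in place of fluoro, on an aromatic carbon ortho to a chloro group and para to a large group, gives a 1.7-fold higher number from compound 1 to compound 4 (0.22 log units; within the scatter) and so provides the first pair that differs in one place. At this position, the two groups are not separated by this measurement. No evidence at hand bears on this result.

As far as these compounds go, whether an amine, a carboxylic acid or a longer chain at this position would give a step beyond the scatter remains open. From the compounds shown here alone, what the chloro group contributes also remains open.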